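Cytotoxicity of three thiocarbamate amides and one nitro analogue

The compounds below may be only part of what the source reports. "The series", "measured", "known", "first", "only" and "open" are said of these compounds alone.

Compound 1, `CCCCCOc1ccc(C(=O)N(C(=S)OCCN2C(=O)c3ccccc3C2=O)c2ccc(F)cc2)cc1`: > 100000 nM
Compound 2, `Cc1ccc(C(=O)N(C(=S)OCCN2C(=O)c3ccccc3C2=O)c2ccc(Cl)cc2)cc1`: > 100000 nM
Compound 3, `Cc1ccc(N(C(=O)c2cccc([N+](=O)[O-])c2)C(=S)OCCN2C(=O)c3ccccc3C2=O)cc1`: 100000 nM

In an ADME assay on MT4 cells (Homo sapiens) for cytotoxicity, read by MTT assay (on this read-out higher numbers stand for lower toxicity in this test and lower numbers for higher toxicity in this test), compound 1 returns only a limit of the test, > 100000 nM. Compound 2 likewise returns only a limit, > 100000 nM, so no number places it within the measured range. Compound 3 gives 100000 nM in this assay, a value that sits right at the same level. Two of the three results therefore rest at the limit of > 100000 nM in this assay, at which 2 of the 3 values shown sit, and compound 2 stands among them, not apart from any other compound.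

Compound 4, `O=C1c2ccccc2C(=O)N1CCOC(=S)N(C(=O)c1cc([N+](=O)[O-])ccc1Cl)c1ccc(Cl)cc1`, has not yet been measured in this assay. It differs from compound 2 by 2-chloro-5-nitrophenyl in place of 4-methylphenyl on a carbonyl carbon. Going by the values given here, with no measured step between compounds to lean on, and with compound 3 carrying a nitrophenyl group and giving 100000 nM, the change is expected to alter toxicity little, if at all, beyond the usual scatter. The expected step is an at least 1.1-fold lower number from compound 2 to compound 4 (0.04 log units; that floor lies within the scatter). Compound 4 is estimated to give about 90000 nM in this assay, within 30000 nM to 200000 nM.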

Compound 4, half-maximal cytotoxic concentration: 45000 nM
For compound 4 the middle estimate is 2.0-fold (0.30 log units) above the measured one; low and high end bracket the measured number.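

Going by these compounds alone, this is the first readable step in the set: in this assay, 2-chloro-5-nitrophenyl in place of 4-methylphenyl on a carbonyl carbon gives an at least 2.2-fold lower number from compound 2 to compound 4 (0.34 log units; beyond the scatter), which lies beyond the scatter and here means higher toxicity in this test. Within the data shown here, the group on this carbonyl carbon, whose other neighbour is the amide-type nitrogen, can therefore shift the reading, which the earlier compounds could not show with no step among them. The size of the shift is known only as a floor because compound 2 rests at a limit of the test: the limit of > 100000 nM in this assay, at which 2 of the 4 values shown sit.

The chlorine and the nitro group enter together, so the compounds shown leave open whether either alone would give this step. They also leave open what an amine or a carboxylic acid on this ring would do to the reading.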